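Benzyl ether in place of aryl ether on the cyclohexyl urea

This account rests on a few compounds, and the source may have more. Where it says the series, first, only, none or still open, it means among the compounds named here.

Compound 1 `O=C(Nc1cccc(C(F)(F)F)c1)N[C@H]1CC[C@H](O)CC1`: in a functional assay on CRL2813 cells (Homo sapiens) for cytotoxicity, read by sulforhodamine B assay, with a stated time of 5 days (a higher number here means a weaker inhibitor, a lower number a stronger inhibitor), compound 1 sits at > 20000 nM, which is a limit of the measurement and not a number.
Compound 2 `O=C(Nc1cccc(C(F)(F)F)c1)N[C@H]1CC[C@H](Oc2cccc(C(F)(F)F)c2)CC1`: in this assay compound 2 gives 1300 nM.
Compound 3 `O=C(Nc1cccc(C(F)(F)F)c1)N[C@H]1CC[C@H](Oc2ccc(Cl)cc2)CC1`: in this assay compound 3 gives 2000 nM.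

Compound 3 holds the highest of the two numbers shown, and its nearest neighbour is compound 2; the step of a 1.5-fold higher number from compound 2 to compound 3 (0.19 log units; within the scatter) is within the scatter, so the two cannot be ordered. The steps that set the scale are an at least 15-fold lower number from compound 1 to compound 2 (1.18 log units; beyond the scatter) and an at least 10-fold lower number from compound 1 to compound 3 (1.00 log units; beyond the scatter), both measured against the limit of compound 1 the limit of > 20000 nM in this assay, at which 1 of the 3 values shown sits: putting an aromatic ring on the oxygen of the saturated carbon moves the number strongly downward, while exchanging one aromatic ring for another hardly moves it.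

Compound 4 `O=C(Nc1cccc(C(F)(F)F)c1)N[C@H]1CC[C@H](OCc2ccc(F)cc2)CC1` differs from compound 3 in one place: 4-fluorobenzyl in place of 4-chlorophenyl on an oxygen on a saturated carbon. For the measured compounds named here, no measured step covers a benzyl group in place of a phenyl group on this oxygen, so the expectation rests on the two aryl ethers alone. As compound 4 keeps an aromatic ring on the oxygen, compound 4 is expected to stay close to compound 3, with the step of a 1.3-fold higher number from compound 3 to compound 4 (0.10 log units; within the scatter) expected to be small. For compound 4 the estimate in this assay is 2500 nM, with a range from 800 nM to 8000 nM.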

Compound 4, half-maximal inhibitory concentration: 2650 nM
Compound 4: middle estimate off by 1.1-fold (0.03 log units), on the low side; the range from low to high includes it.
By their numbers in this assay, from the lowest: compounds 2, 3 and 4 (each within the scatter of the next, the first and the last beyond it). At a limit, above all of these: compound 1.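

The ring on this oxygen need not be attached directly to it: with 4-fluorobenzyl in place of 4-chlorophenyl the step reads a 1.3-fold higher number from compound 3 to compound 4 (0.12 log units; within the scatter), so the two cannot be ordered in this assay. Against the 3-(trifluoromethyl)phenyl ether the same benzyl ether gives a 2.0-fold higher number from compound 2 to compound 4 (0.31 log units; beyond the scatter), a modest step only just past the scatter, which makes compounds 2 and 4 the only pair among the three ethers that can be told apart. The benzyl ether also keeps its distance from the free hydroxyl, an at least 7.5-fold lower number from compound 1 to compound 4 (0.87 log units; beyond the scatter), and the size of that step is fixed only by compound 1, which stands at a limit and not a number: the limit of > 20000 nM in this assay, at which 1 of the 4 values shown sits.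

On these data alone, compound 4 brings the added carbon and the exchange of chlorine for fluorine together, so the part each plays stays open, and an unsubstituted benzyl ether or a 4-chlorobenzyl ether would separate them. Also open, as far as these compounds go, is whether this oxygen needs an aromatic ring at all, which a plain methyl ether, or an amine on the same saturated carbon, would test.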